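Carbamoyl-bearing chain in place of the methoxy chain

A few compounds are considered here, and "the series" means these few. Any claim that something is new, unique, unknown or untested is made for them only; others in the source may bear on it.

The shared core carries a chain on a saturated chain carbon bound to a triple-bonded carbon, and three variants of that chain have been measured. Compound 1 `CC(C)(C#N)CC#Cc1c(Cl)c2c(Cl)cc(C(N)=O)nc2n1[C@H]1CCCNC1` gives 113 nM in a functional assay on KG-1 cells (Homo sapiens) for antiproliferative activity; on this read-out lower numbers stand for an effect already at smaller amounts and higher numbers for an effect only at larger amounts of compound. Compound 2 `COCCC#Cc1c(Cl)c2c(Cl)cc(C(N)=O)nc2n1[C@H]1CCCNC1` gives 39 nM in this assay, the lowest of the two single numbers, with compound 1 the nearest at a 2.9-fold lower number from compound 1 to compound 2 (0.46 log units; beyond the scatter). Compound 3 `NC(=O)c1cc(Cl)c2c(Cl)c(C#CC3CNCCO3)n([C@H]3CCCNC3)c2n1` has been measured more than once in this assay and gives 365 nM; 197 nM (2 entries); the spread of its entries the several entries of compound 3 in this assay, 365 nM; 197 nM (2 entries) shows how far repeated values of this kind drift. Compound 4 `CC(C)(CC#Cc1c(Cl)c2c(Cl)cc(C(N)=O)nc2n1[C@H]1CCCNC1)C(N)=O` has not been measured. It differs from compound 2 by 1-carbamoyl-1-methylethyl in place of methoxymethyl on a saturated chain carbon bound to a triple-bonded carbon. Among the compounds with values here, the only measured step that bears on this change is the one from compound 1 to compound 2, where the 1-cyano-1-methylethyl group gave the higher number; compound 4 returns to a branched chain of that kind with a carbamoyl in place of the nitrile, so a step back toward compound 1 is expected. Compound 4 is therefore estimated at 100 nM in this assay, within 40 nM to 250 nM, which would mean an expected step of a 2.6-fold higher number from compound 2 to compound 4 (0.41 log units; beyond the scatter).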

Compound 4, half-maximal effective concentration: 269 nM
Compound 4: middle estimate off by 2.7-fold (0.43 log units), on the low side; measured number above the stated range.
By their numbers in this assay, from the lowest: compound 2; then compound 1; then compound 4.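

In this assay, the chain ending in carbamoyl lies well away from the methoxy chain, with a 6.9-fold higher number from compound 2 to compound 4 (0.84 log units; beyond the scatter), so neither branched chain shown comes close to the value of the methoxy chain. The exchange of nitrile for carbamoyl on the same branched chain is also a change that registers on its own, with a 2.4-fold higher number from compound 1 to compound 4 (0.38 log units; beyond the scatter), so the higher number at this position does not depend on the nitrile alone. Repeated values of a single compound give the yardstick for reading these steps: the several entries of compound 3 in this assay, 365 nM; 197 nM (2 entries)

The compounds shown cannot separate the effect of the two methyl groups from that of the end group, since no unbranched chain ending in carbamoyl or nitrile stands among them. They also leave open how a chain ending in an amine or a carboxylic acid would read in this assay.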